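Aryl swap on the chain end: from compound 1 to compound 4

A few compounds are considered here, and "the series" means these few. Any claim that something is new, unique, unknown or untested is made for them only; others in the source may bear on it.

Measured so far in a functional assay on ASPC1 cells (Homo sapiens) for inhibition, read by MTT assay, with a stated time of 72 h; on this read-out higher numbers stand for weaker inhibition of growth and lower numbers for stronger inhibition of growth:
compound 1 `CC(C)(C)c1ccc(CNCCCNS(=O)(=O)c2cc(C(F)(F)F)cc(C(F)(F)F)c2)cc1` gives 2700 nM
compound 2 `COc1cccc(CNCCCNS(=O)(=O)c2cc(C(F)(F)F)cc(C(F)(F)F)c2)c1` gives 3800 nM
compound 3 `O=S(=O)(NCCCNCc1ccc(Br)cc1)c1cc(C(F)(F)F)cc(C(F)(F)F)c1` gives 2800 nM

Compound 1 has the lowest of the three numbers, but the gap to each of the others is within the scatter: the nearest is compound 3, a 1.0-fold higher number from compound 1 to compound 3 (0.02 log units; within the scatter), the furthest is compound 2, a 1.4-fold higher number from compound 1 to compound 2 (0.15 log units; within the scatter). The remaining pair is likewise flat, a 1.4-fold lower number from compound 2 to compound 3 (0.13 log units; within the scatter). Three aryl groups on the saturated chain carbon bound to the amine nitrogen thus give numbers that cannot be told apart in this assay.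

Compound 4 `O=S(=O)(NCCCNCc1ccc(Cl)c(Cl)c1)c1cc(C(F)(F)F)cc(C(F)(F)F)c1` is the next member. Relative to compound 1 the change is 3,4-dichlorophenyl in place of 4-(tert-butyl)phenyl on a saturated chain carbon bound to an amine nitrogen. The two steps that bear on it are the ones already made at this position: bromo in place of tert-butyl on an aromatic carbon, a 1.0-fold higher number from compound 1 to compound 3 (0.02 log units; within the scatter), and 3-methoxyphenyl in place of 4-(tert-butyl)phenyl, a 1.4-fold higher number from compound 1 to compound 2 (0.15 log units; within the scatter). Neither moved the read-out beyond the scatter, so the expectation for compound 4 is a step of no size beyond the scatter in this assay, a 1.0-fold higher number from compound 1 to compound 4 (0.02 log units; within the scatter), with the direction left open. The estimated value for compound 4 is therefore 2800 nM, with a range from 1300 nM to 6000 nM.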

Compound 4, concentration for 50% growth inhibition: 2800 nM
Compound 4: middle estimate and measured number agree at the digits printed; the measured number falls inside the stated range.
By their numbers in this assay, from the lowest: compounds 1, 3, 4 and 2 (each within the scatter of the next).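

In this assay the 3,4-dichlorophenyl group of compound 4 stays level with each of the three earlier aryl groups at this place, whether set against 4-(tert-butyl)phenyl (a 1.0-fold higher number from compound 1 to compound 4 (0.02 log units; within the scatter)), 4-bromophenyl (no change at the digits printed from compound 3 to compound 4 (within the scatter)) or 3-methoxyphenyl (a 1.4-fold lower number from compound 2 to compound 4 (0.13 log units; within the scatter)). Among the compounds shown here, the flat picture therefore now extends to an aryl group bearing two chlorine atoms, and across compounds 1 to 4 no compound goes against it, so swapping between these four aryl groups on the saturated chain carbon bound to an amine nitrogen gives no handle on the read-out. No measurement is at hand that would account for this flatness.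

The compounds shown leave open whether the read-out would respond to a carboxylic acid or a primary amine on the aryl ring, or to a cyclohexyl group or a pyridine ring in place of the aryl group. They also leave open what a longer chain between the two nitrogen atoms would do, or a replacement of the trifluoromethyl groups, since both parts of the core are the same in all four compounds.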